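From (furan-2-yl)methyl to 1-methylheptyl: cytotoxicity working notes

The source may report more compounds than this note shows. Statements on the series, on what has been measured and on what is new or still open speak of the compounds shown alone.

In an ADME assay on A549 cells (Homo sapiens) for cytotoxicity, read by LDH release, with a stated time of 15 h (a lower number here means that less compound is tolerated, a higher number that more compound is tolerated), compound 1 `O=C(Nc1ccc(NC2CCCC2)cc1Cl)c1cc(Cl)ccc1O` has the entry "not determined" (no result reported). Within the data shown here, compound 2 `O=C(Nc1ccc(NCc2ccco2)cc1Cl)c1cc(Cl)ccc1O` gives 76300 nM, the only number, so its standing cannot be ranked. Next is compound 3 `CCCCCCC(C)Nc1ccc(NC(=O)c2cc(Cl)ccc2O)c(Cl)c1`: 1-methylheptyl in place of (furan-2-yl)methyl on a nitrogen on an aromatic ring. Here 1-methylheptyl sits in place of (furan-2-yl)methyl on a nitrogen on an aromatic ring. Among the measured compounds shown here, no measured step exists to set a size, so on the structural change alone a moderate fall in tolerated concentration is expected, with wide uncertainty. The estimated change is a 3.1-fold lower number from compound 2 to compound 3 (0.48 log units; beyond the scatter). In this assay, the expected value for compound 3 is 25000 nM, within a range of 7000 nM to 80000 nM.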

Compound 3, half-maximal cytotoxic concentration: 18600 nM
Beside the measured number, compound 3's estimate is 1.3-fold (0.13 log units) above it, within the range that was stated.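

In this assay, 1-methylheptyl in place of (furan-2-yl)methyl on a nitrogen on an aromatic ring gives a 4.1-fold lower number from compound 2 to compound 3 (0.61 log units; beyond the scatter) and shows that this position can move the read-out beyond the scatter. Among these compounds, the single step cannot separate loss of the five-membered aromatic ring from the change to an open chain. No evidence bears on the cause of this step.

From the compounds shown here alone, whether a shorter chain such as butyl or a saturated ring such as tetrahydrofuran-2-ylmethyl would stand nearer compound 2 or compound 3 remains open. Going by these compounds, the effect of a chain carrying an amine or a carboxylic acid also remains open.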